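Trifluoromethyl replacing methoxy on the indole of compound 3

This account rests on a few compounds, and the source may have more. Where it says the series, first, only, none or still open, it means among the compounds named here.

Compound 3 `COC(=O)[C@@]1(C)CCC=C2[C@@H]1CC[C@@H](C)[C@]2(C)Cc1c[nH]c2ccc(OC)cc12` gives the lowest number of the three compounds measured in a functional assay on HBL-100 cells (Homo sapiens) for inhibition, read by sulforhodamine B assay, with a stated time of 48 h; on this read-out lower numbers stand for stronger inhibition of growth and higher numbers for weaker inhibition of growth: compound 3 gives 2100 nM, compound 1 `COC(=O)[C@@]1(C)CCC=C2[C@@H]1CC[C@@H](C)[C@]2(C)Cc1c[nH]c2ccccc12` gives 4500 nM, and compound 2 `COC(=O)[C@@]1(C)CCC=C2[C@@H]1CC[C@@H](C)[C@]2(C)Cc1c[nH]c2ccc(Cl)cc12` gives 17000 nM. Compound 4 `COC(=O)[C@@]1(C)CCC=C2[C@@H]1CC[C@@H](C)[C@]2(C)Cc1c[nH]c2ccc(C(F)(F)F)cc12` differs from compound 3 by trifluoromethyl in place of methoxy on an aromatic carbon. Among the measured compounds shown here, no measured step introduces a trifluoromethyl group, so the bearing steps are indirect: a 2.1-fold lower number from compound 1 to compound 3 (0.33 log units; beyond the scatter), a 3.8-fold higher number from compound 1 to compound 2 (0.58 log units; beyond the scatter) and an 8.1-fold lower number from compound 2 to compound 3 (0.91 log units; beyond the scatter). The one substituent at this position that is neither hydrogen nor methoxy, the chloro of compound 2, carried the highest number of the set, and the removal of the methoxy in the step from compound 3 would give up the gain seen in a 2.1-fold lower number from compound 1 to compound 3 (0.33 log units; beyond the scatter). He therefore expects a step to a higher number, estimated as a 4.3-fold higher number from compound 3 to compound 4 (0.63 log units; beyond the scatter) in this assay. Compound 4 is expected to give about 9000 nM in this assay, with a range from 3000 nM to 27000 nM.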

Compound 4, concentration for 50% growth inhibition: 15000 nM
For compound 4 the middle estimate is 1.7-fold (0.22 log units) below the measured one; the range from low to high includes it.
By their numbers in this assay, from the lowest: compound 3; then compound 1; then compounds 4 and 2 (each within the scatter of the next).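

In this assay the change from methoxy to trifluoromethyl gives up the advantage held by compound 3, with a 7.1-fold higher number from compound 3 to compound 4 (0.85 log units; beyond the scatter). Trifluoromethyl also does worse than hydrogen, with a 3.3-fold higher number from compound 1 to compound 4 (0.52 log units; beyond the scatter), so compound 2 is no longer the only compound whose substituent here stands on the weaker side of compound 1. Trifluoromethyl and chloro cannot be told apart at this position, with a 1.1-fold lower number from compound 2 to compound 4 (0.05 log units; within the scatter), and among the four compounds only methoxy improves on hydrogen, though nothing shown gives a reason for these differences.

From the compounds shown here alone, whether the advantage belongs to methoxy alone or extends to groups such as hydroxyl, ethoxy or an amine remains open. So does whether these substituents would rank the same way on another carbon of this aromatic ring.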